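Toward compound 4: isobutyl in place of cyclohexyl

The source may report more compounds than this note shows. Statements on the series, on what has been measured and on what is new or still open speak of the compounds shown alone.

Measured in a functional assay on NUGC-3 cells (Homo sapiens) for antiproliferative activity, read by sulforhodamine B assay; on this read-out lower numbers stand for stronger inhibition of growth and higher numbers for weaker inhibition of growth:
- compound 1 `CC(C)CCCOc1cccc(O)c1C(=O)/C=C/c1ccc(O)cc1`: 3520 nM
- compound 2 `CCCCCCOc1cccc(O)c1C(=O)/C=C/c1ccc(O)cc1`: > 30000 nM (a limit)
- compound 3 `O=C(/C=C/c1ccc(O)cc1)c1c(O)cccc1OCC1CCCCC1`: > 30000 nM (a limit)

Compound 3 gives only a limit: the limit of > 30000 nM in this assay, at which 2 of the 3 values shown sit. Compound 4 `CC(C)CCOc1cccc(O)c1C(=O)/C=C/c1ccc(O)cc1` differs from compound 3 by isobutyl in place of cyclohexyl on a saturated chain carbon bound to an oxygen on an aromatic ring, which is isobutyl in place of cyclohexyl on a saturated chain carbon bound to an oxygen on an aromatic ring. Going by the values given here, two measured steps bear on this: an at least 8.5-fold higher number from compound 1 to compound 3 (0.93 log units; beyond the scatter) and an at least 8.5-fold higher number from compound 1 to compound 2 (0.93 log units; beyond the scatter). Both lie beyond the scatter, and both are bounded by a limit. Compound 4 shares the isopropyl group of compound 1, at 3520 nM, so a lower number is expected in this assay. A limit remains possible for compound 4. The expected step is an at least 3.7-fold lower number from compound 3 to compound 4 (0.57 log units; beyond the scatter). For compound 4 the estimate is 8000 nM, with an expected range of 2500 nM to 26000 nM.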

Compound 4, concentration for 50% growth inhibition: 12400 nM
Compound 4: the middle estimate sits 1.6-fold (0.19 log units) below what was measured; the measured number falls inside the stated range.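

In this assay, isopentyl in place of cyclohexylmethyl brings a measurable value, with an at least 2.4-fold lower number from compound 3 to compound 4 (0.38 log units; beyond the scatter), and the same holds against the straight chain, with an at least 2.4-fold lower number from compound 2 to compound 4 (0.38 log units; beyond the scatter). The isopropyl group shared with compound 1 does not alone set the value, with a 3.5-fold higher number from compound 1 to compound 4 (0.55 log units; beyond the scatter). Compound 2 and compound 3 remain limits, so those two steps give only a minimum size: the limit of > 30000 nM in this assay, at which 2 of the 4 values shown sit.

Still open, going by these compounds, is how the series responds to a longer branched chain, or to a chain ending in an amine or a carboxylic acid.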